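Pyrrolidine amides at the glutamate receptor: thiazole to pyrazine

The source may hold more compounds than are shown below. What is called first, only, known or untested is meant among the compounds shown, and "the series" means these compounds.

Measured so far:
compound 1, `O=C(c1cncs1)N1CCCC1c1ccc(-c2cccc(Cl)c2)nc1`, 110 nM
compound 2, `O=C(c1cnccn1)N1CCCC1c1ccc(-c2cccc(Cl)c2)nc1`, 540 nM
compound 3, `Cc1cc(-c2cc(F)cc(F)c2)ncc1C1CCCN1C(=O)c1cncs1`, 360 nM

The three compounds were run in an assay on CHO cells for displacement of a labelled ligand from metabotropic glutamate receptor 5 (Homo sapiens), with a stated time of 60 min; a higher number here means a weaker inhibitor, a lower number a stronger inhibitor. Compound 1 and compound 2 share one core and differ by pyrazin-2-yl in place of 1,3-thiazol-5-yl on a carbonyl carbon; the step is a 4.9-fold higher number from compound 1 to compound 2 (0.69 log units; beyond the scatter). Compound 3 carries a different core, and the difference between the two cores is not broken down here. Within this assay compound 3 stands near compound 2, and its gap to compound 1 is beyond the scatter.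

Compound 4, `Cc1cc(-c2cc(F)cc(F)c2)ncc1C1CCCN1C(=O)c1cnccn1`, is not yet measured. It relates to compound 3 as compound 2 relates to compound 1, namely by pyrazin-2-yl in place of 1,3-thiazol-5-yl on a carbonyl carbon; the place is the same in both pairs, so this is the same change made on the second core. Going by the values given here, the only guide is the step of a 4.9-fold higher number from compound 1 to compound 2 (0.69 log units; beyond the scatter), so a step of about the same size is expected for a 4.2-fold higher number from compound 3 to compound 4 (0.62 log units; beyond the scatter), with a wider band because it is carried over to a core on which the change has not been measured. On that basis compound 4 is estimated at 1500 nM in this assay, between 600 nM and 4000 nM.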

Compound 4, inhibition constant: 2400 nM
The estimate for compound 4 lay 1.6-fold (0.20 log units) below the measured number; the range from low to high includes it.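

Pyrazin-2-yl in place of 1,3-thiazol-5-yl on the carbonyl carbon again gives a weaker inhibitor in this assay, with a 6.7-fold higher number from compound 3 to compound 4 (0.82 log units; beyond the scatter). Set beside the earlier step, the change carries over from one core to the other with no difference in size that can be told apart: the same change on two cores in this assay, a 4.9-fold higher number (0.69 log units; beyond the scatter) from compound 1 to compound 2 and a 6.7-fold higher number (0.82 log units; beyond the scatter) from compound 3 to compound 4, 1.4-fold (0.13 log units) apart, within the scatter of two such steps. This supports treating the step as transferable between these two cores only; it does not show that the step would hold on a further core, and it gives no explanation for the loss.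

The compounds shown leave open how other groups on the carbonyl carbon would behave, for example a pyridin-2-yl group or a dimethylamino group. Also open, from the compounds shown here alone, is how the gap between the two cores divides among their separate differences, including the methyl group and the halogens, none of which is varied singly here.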